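Changing the Linker in Compound 4

The compounds below may be only part of what the source reports. "The series", "measured", "known", "first", "only" and "open" are said of these compounds alone.

Compound 3 `COc1cc(Cl)cc(-c2nn(-c3cccc(NC(=O)Nc4cccc(C(F)(F)F)c4)c3)cc2-c2ccncc2)c1` was measured in a functional assay on NCI-H522 cells (Homo sapiens) for inhibition, read by sulforhodamine B assay, with a stated time of 48 h, tested at 0.1 uM (a lower number here means a stronger effect, a higher number a weaker effect of the compound at the concentration tested), where compound 3 gives 53%. This places compound 3 level with compound 2 `COc1cc(Cl)cc(-c2nn(-c3cccc(NC(=O)Nc4ccc(Cl)c(Cl)c4)c3)cc2-c2ccncc2)c1`, which gives 53%, the two together being the lowest of three numbers. Compound 1 `COc1cc(Cl)cc(-c2nn(-c3cccc(NC(=O)Nc4ccc(Cl)c(C(F)(F)F)c4)c3)cc2-c2ccncc2)c1` gives 77%, and the step is a number 24 percentage points lower from compound 1 to compound 3 (beyond the scatter). Compound 4 `COc1cc(Cl)cc(-c2nn(-c3cccc(NC(=O)c4cccc(C(F)(F)F)c4)c3)cc2-c2ccncc2)c1` differs from compound 3 by 3-(trifluoromethyl)phenyl in place of (3-(trifluoromethyl)phenyl)amino on a carbonyl carbon. Within the data shown here, none of the measured steps touches this place: a number 24 percentage points lower from compound 1 to compound 2 (beyond the scatter) and no change at the digits printed from compound 2 to compound 3 (within the scatter) both concern the outer aromatic ring, not the carbonyl carbon. With nothing bearing directly on the change, a small step or none beyond the scatter is expected, so compound 4 is estimated at 60%, within 40% to 85%, an expected step of a number 7 percentage points higher from compound 3 to compound 4 (within the scatter).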

Compound 4, a percentage reported as activity, at one concentration (the size of the read-out at that concentration, not a potency): 83%
Estimate against measurement, compound 4: 23 percentage points below; measured number inside the range.
By their numbers in this assay, from the lowest: compounds 2 and 3 (each within the scatter of the next); then compounds 1 and 4 (each within the scatter of the next).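

At the carbonyl carbon, 3-(trifluoromethyl)phenyl replaces the (3-(trifluoromethyl)phenyl)amino group and removes its hydrogen-bond donor, and in this assay this gives a number 30 percentage points higher from compound 3 to compound 4 (beyond the scatter). Against the other amino compound with a lower number there is a number 30 percentage points higher from compound 2 to compound 4 (beyond the scatter), so the number responds to this place as well as to the outer ring. Yet a number 6 percentage points higher from compound 1 to compound 4 (within the scatter), so compound 4 cannot be separated from compound 1.

Nothing shown here gives a reason for the step. From the compounds shown here alone, how a methylene or sulfonyl group at this carbonyl position would read remains open.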